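The source may report more compounds than this note shows. Statements on the series, on what has been measured and on what is new or still open speak of the compounds shown alone.

In a functional assay on blood (Homo sapiens), with a stated time of 60 min, in the presence of a further agent that is not named here (on this read-out lower numbers stand for an effect already at smaller amounts and higher numbers for an effect only at larger amounts of compound), compound 1 `Nc1ccccc1NC(=O)C1(S(=O)(=O)c2ccc(Oc3ccc(OC(F)(F)F)cc3)cc2)CCC2(CCNCC2)C1`, which carries 2-aminophenyl on an amide-type nitrogen, gives 900 nM. Compound 2 `CCCN1CCC2(CC1)CCC(C(=O)NC(=O)NC)(S(=O)(=O)c1ccc(Oc3ccc(OC(F)(F)F)cc3)cc1)C2` stands at > 15000 nM in this assay, and this is a limit of the assay, not a number. Compound 3 `CCCN1CCC2(CC1)CCC(C(=O)Nc1ccccc1N)(S(=O)(=O)c1ccc(Oc3ccc(OC(F)(F)F)cc3)cc1)C2` has 2-aminophenyl in place of methylcarbamoyl on an amide-type nitrogen of compound 2 (2-aminophenyl in place of methylcarbamoyl on an amide-type nitrogen). With compound 1 at 900 nM carrying that same group, a large move toward lower numbers, well beyond the scatter, is expected. The expected step is an at least 15-fold lower number from compound 2 to compound 3 (1.17 log units; beyond the scatter). The estimate for compound 3 is 1000 nM, within an expected range of 250 nM to 5000 nM.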

Compound 3, half-maximal effective concentration: <= 400 nM
Compound 3 gave a limit, no number (the forecaster's own chance of this, stated with the estimate: 8%); middle value at least 2.5-fold (0.39 log units) from the limit.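

Putting 2-aminophenyl in place of methylcarbamoyl on the amide-type nitrogen gives an at least 37-fold lower number from compound 2 to compound 3 (1.57 log units; beyond the scatter), which shows that this one position carries a large effect while the rest of the molecule stays the same. With 2-aminophenyl kept, propyl in place of hydrogen on the amine nitrogen in the ring gives an at least 2.2-fold lower number from compound 1 to compound 3 (0.35 log units; beyond the scatter), so the gain survives that propyl group and goes further. On these data alone, both steps rest on limits of the assay, not on numbers, and their true sizes remain unknown.

The compounds shown leave open whether a plain phenyl, without the amine, would hold this gain. They also leave open whether a butyl chain on the ring nitrogen would shift the number further.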